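Rat plasma stability of three prodrug esters in a series

The source may hold more compounds than are shown below. What is called first, only, known or untested is meant among the compounds shown, and "the series" means these compounds.

Measured compounds and their stability values:
- compound 1, `C[C@@H](O)[C@H]1C(=O)N2C3=C(S[C@@H]4CN[C@@H](C4)C(=O)Nc4cccc(c4)C(=O)OCOCOC3=O)[C@H](C)[C@H]12`: 0%
- compound 2, `C[C@@H](O)[C@H]1C(=O)N2C(C(=O)OCOC(=O)C3CCCCC3)=C(S[C@@H]3CN[C@H](C(=O)Nc4cccc(C(=O)O)c4)C3)[C@H](C)[C@H]12`: 0%
- compound 3, `C[C@@H](O)[C@H]1C(=O)N2C(C(=O)OCOC(=O)C3CCCCC3)=C(S[C@@H]3CN[C@H](C(=O)Nc4cccc(C(=O)OCOC(=O)C5CCCCC5)c4)C3)[C@H](C)[C@H]12`: 10%

In an ADME assay on a cell-free system (plasma, Rattus norvegicus) for metabolic stability, read by LC-MS, with a stated time of 60 min, at 37 degrees C, tested at 50 uM (on this read-out higher numbers stand for a more stable compound and lower numbers for a less stable compound), compound 2 gives 0%. Compound 2 stands level with compound 1 at the digits shown; together they are the lowest of the three numbers. Compound 3 lies furthest from compound 2, and that step, a number 10 percentage points higher from compound 2 to compound 3 (within the scatter), is within the scatter, so no ordering between these compounds can be read from the values.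

The next compound, compound 4, is `COC(=O)OCOC(=O)C1=C(S[C@@H]2CN[C@H](C(=O)Nc3cccc(C(=O)O)c3)C2)[C@H](C)[C@@H]2[C@@H]([C@@H](C)O)C(=O)N12`. It differs from compound 2 as follows: methoxy in place of cyclohexyl on a carbonyl carbon. Within the data shown here, the only measured step that touches the same region of the structure is the one from compound 2 to compound 3, where a larger group was added at the acid and the number moved by a number 10 percentage points higher from compound 2 to compound 3 (within the scatter), within the scatter. The change to compound 4 is smaller in kind, exchanging one group on the carbonyl carbon for another, and nothing in the measured series shows a move beyond the scatter for changes of this sort. The expected step is therefore a number 2 percentage points higher from compound 2 to compound 4 (within the scatter), none beyond the scatter.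

For compound 4 the estimate in this assay is 2%, with a range from 0% to 12%.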

Compound 4, percent of the compound remaining: 0%
For compound 4 the middle estimate is 2 percentage points above the measured one, within the range that was stated.
By their numbers in this assay, from the lowest: compounds 1, 2, 4 and 3 (each within the scatter of the next).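

In this assay, among these compounds, this is the first reading of a change within the ((cyclohexylcarbonyl)oxy)methyl group itself, on a carbonyl carbon whose other neighbours are oxygen next to a carbonyl group: methoxy in place of cyclohexyl gives no change at the digits printed from compound 2 to compound 4 (within the scatter). The six-membered carbon ring can therefore go without any shift in the number, although at this bottom end of the read-out only a rise could register, and none appears. No other data bear on this result. Going by these compounds, whether an amine or a longer chain on this carbonyl carbon would lift the number beyond the scatter remains open. Also open, on these data alone, is whether methoxy gives the same reading when the acid carries ((cyclohexylcarbonyl)oxy)methyl, as it does in compound 3.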